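This account rests on a few compounds, and the source may have more. Where it says the series, first, only, none or still open, it means among the compounds named here.

Working notes on the series. Three compounds carry a number in a functional assay on the whole organism for displacement of a labelled ligand, with Rattus norvegicus as the target, at a dose of 3.2 mg/kg by the subcutaneous route; a higher number here means more inhibition at the dose given (going by the name of the read-out), a lower number less inhibition. Compound 1 `C/C=C(\CC)Oc1cc(C)nc(Oc2c(C)cc(C)cc2C)c1C` gives 55% in this assay, which is the second highest of the three. Compound 3 `CCC(CC)Oc1cc(C)nc(Oc2c(C)cc(I)cc2C)c1C` gives 72% in this assay, a number above that of compound 1 by more than the usual scatter. Compound 2 `CCC(CC)Oc1cc(C)nc(Oc2c(C)cc(C)cc2C)c1[N+](=O)[O-]` gives 35% in this assay, below compound 1 by more than the scatter. For the measured compounds named here, compound 2 and compound 3 each differ from compound 1 in more than one place, so no single-point step between measured compounds can be read from these three, and the two values only bracket compound 1 from both sides.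

Compound 4 `CCC(C)Oc1cc(C)nc(Oc2c(C)cc(C)cc2C)c1C` has not been measured in this assay. Against compound 1 the change is sec-butyl in place of 1-ethylprop-1-en-1-yl on an oxygen on an aromatic ring: a group of 5 heavy atoms with 1 double bond outside aromatic rings gives way to one of 4 heavy atoms with no double bond, on the same oxygen. Going by the values given here, nothing among the measured compounds isolates this change. The step of a number 5 percentage points lower from compound 1 to compound 4 (within the scatter) is expected to be modest, most likely within the scatter or a slight fall. Compound 4 is therefore estimated at 50% in this assay, within 30% to 70%.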

Compound 4, a percentage reported as inhibition, in the whole organism at one dose (the size of the read-out at that dose, not a potency): 42%
The estimate for compound 4 lay 8 percentage points above the measured number; low and high end bracket the measured number.
By their numbers in this assay, from the lowest: compounds 2 and 4 (each within the scatter of the next); then compound 1; then compound 3.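

In this assay, for the compounds shown here, the swap of 1-ethylprop-1-en-1-yl for sec-butyl on an oxygen on an aromatic ring is a step of a number 13 percentage points lower from compound 1 to compound 4 (beyond the scatter), the first change that can be read at a single place. It shows that the read-out at this dose responds to the group on this oxygen, even when the change is as small as going from 5 heavy atoms with 1 double bond outside aromatic rings to 4 heavy atoms with none. Nothing measured on these compounds bears on the reason for this step, so it stands as an observation only.

The step combines two differences, the size of the group and the loss of the double bond, and these compounds do not show which of them carries it or whether either would do so alone. Also open, as far as these compounds go, is how the read-out would respond on this oxygen to a ring such as cyclopentyl or to a longer chain such as hexyl, and whether an amine such as diethylamino could take the place of the whole sec-butoxy group.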